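The source may report more compounds than this note shows. Statements on the series, on what has been measured and on what is new or still open speak of the compounds shown alone.

Compound 1 `CCC(C)n1ncn(-c2ccc(N3CCN(c4ccc(OC[C@@H]5CO[C@@](Cn6ccnc6C)(c6ccc(Cl)cc6Cl)O5)cc4)CC3)cc2)c1=O`: 173 nM
Compound 2 `CCC(C)n1ncn(-c2ccc(N3CCN(c4ccc(OC[C@@H]5CO[C@@](Cn6cc(C)nc6C)(c6ccc(Cl)cc6Cl)O5)cc4)CC3)cc2)c1=O`: 492 nM
Compound 3 `CCC(C)n1ncn(-c2ccc(N3CCN(c4ccc(OC[C@@H]5CO[C@@](Cn6c(C)cnc6C)(c6ccc(Cl)cc6Cl)O5)cc4)CC3)cc2)c1=O`: 765 nM

All three were tested in a functional assay on HUVEC cells (Homo sapiens), read by scintillation counting and thymidine incorporation, with a stated time of 24 h; a higher number here means a weaker inhibitor, a lower number a stronger inhibitor. Compound 1 gives the lowest of the three numbers, so it is the strongest inhibitor of the set; its nearest neighbour is compound 2, with a 2.8-fold higher number from compound 1 to compound 2 (0.45 log units; beyond the scatter), and compound 3 lies furthest, with a 4.4-fold higher number from compound 1 to compound 3 (0.65 log units; beyond the scatter). Between the two weaker compounds the step is a 1.6-fold higher number from compound 2 to compound 3 (0.19 log units; within the scatter).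

Compound 4 `CCC(C)n1ncn(-c2ccc(N3CCN(c4ccc(OC[C@@H]5CO[C@@](Cn6nnnc6-c6ccccc6)(c6ccc(Cl)cc6Cl)O5)cc4)CC3)cc2)c1=O` has not yet been measured. It differs from compound 1 in one place: 5-phenyl-1H-tetrazol-1-yl in place of 2-methyl-1H-imidazol-1-yl on a saturated chain carbon bound to a saturated ring carbon

Within the data shown here, no measured step swaps this ring for another, so the comparison is indirect. The two steps that alter the same ring, a 2.8-fold higher number from compound 1 to compound 2 (0.45 log units; beyond the scatter) and a 4.4-fold higher number from compound 1 to compound 3 (0.65 log units; beyond the scatter), each add a single methyl and each weaken inhibition modestly. Compound 4 carries a much larger group at that place, so a weakening step is expected, with wide uncertainty. For compound 4 the expected step is a 4.0-fold higher number from compound 1 to compound 4 (0.61 log units; beyond the scatter). Compound 4 is therefore estimated at 700 nM, within 200 nM to 2500 nM.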

Compound 4, half-maximal inhibitory concentration: 119 nM
The estimate for compound 4 lay 5.9-fold (0.77 log units) above the measured number; measured number outside the range, below it.
By their numbers in this assay, from the lowest: compounds 4 and 1 (each within the scatter of the next); then compounds 2 and 3 (each within the scatter of the next).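

In this assay, replacing 2-methyl-1H-imidazol-1-yl with 5-phenyl-1H-tetrazol-1-yl gives a 1.5-fold lower number from compound 1 to compound 4 (0.16 log units; within the scatter) and so no readable change, even though the entering group has 11 heavy atoms against 6. Single added methyls on the imidazole ring weakened inhibition, yet the larger group gives a 4.1-fold lower number from compound 2 to compound 4 (0.62 log units; beyond the scatter) and a 6.4-fold lower number from compound 3 to compound 4 (0.81 log units; beyond the scatter) against the two dimethyl compounds, so among these compounds a larger group at this place does not by itself mean a weaker inhibitor. Nothing measured here gives a reason for this result.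

Going by these compounds, the ring and the phenyl change together, so the share of each stays open; a tetrazole carrying methyl, or an imidazole carrying phenyl, would separate them. On these data alone, whether an amine or a carboxylic acid at this place would fit the same pattern also remains open.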